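Amino in place of nitro on the shared core

The compounds below may be only part of what the source reports. "The series", "measured", "known", "first", "only" and "open" are said of these compounds alone.

In an ADME assay on MIA PaCa-2 cells (Homo sapiens) for cytotoxicity, read by MTT assay, with a stated time of 72 h (a higher number here means a weaker inhibitor, a lower number a stronger inhibitor), compound 1 (`COc1ccc(C2=C(c3cc(OC)c(OC)c(OC)c3)CC(O)C2=O)cc1[N+](=O)[O-]`) gives > 100 ug/mL as a limit of the assay and not a number. Compound 2 (`COc1ccc(C2=C(c3cc(OC)c(OC)c(OC)c3)CC(O[SiH2]C(C)(C)C)C2=O)cc1[N+](=O)[O-]`) gives > 100 ug/mL as a limit too. The evidence so far is the limit of > 100 ug/mL in this assay, at which 2 of the 2 values shown sit, and nothing finer. For the measured compounds named here, the one measured step, a step that the two limits leave unreadable from compound 1 to compound 2, gives no size to carry forward, and it lies at another place on the core. Compound 3 (`COc1ccc(C2=C(c3cc(OC)c(OC)c(OC)c3)CC(O)C2=O)cc1N`) carries amino in place of nitro on an aromatic carbon, and amino in place of nitro on an aromatic carbon sets out that change in full. Going by the values given here, no measured step touches this place, so the data fix no size for it. In this assay the expected step is an at least 3.3-fold lower number from compound 1 to compound 3 (0.52 log units; beyond the scatter) towards stronger inhibition, and this is only a loose expectation. For compound 3 the estimate is 30 ug/mL within an expected range of 0.5 ug/mL to 150 ug/mL and a further limit remains possible.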

Compound 3, half-maximal inhibitory concentration: > 100 ug/mL
Compound 3 gave a limit, no number; the forecaster's own chance of this, stated with the estimate: 40%; middle value at least 3.3-fold (0.52 log units) away from the limit.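

In this assay compound 3 gives > 100 ug/mL, a limit of the assay and not a number. For the compounds shown here, compound 1 also stands at a limit, so no step between compound 1 and compound 3 can be read. The compounds shown leave open whether amino in place of nitro on an aromatic carbon changes the number in this assay at all, and by how much.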